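Swapping methylsulfonyl for acetyl on a long-lived compound

The compounds below may be only part of what the source reports. "The series", "measured", "known", "first", "only" and "open" are said of these compounds alone.

Compound 1 `CS(=O)(=O)NC1CCC(CN2CCN(c3cc(=O)c4cc(C(F)(F)F)cc([N+](=O)[O-])c4s3)CC2)CC1` gives > 1.55 h as a limit, not a number
Compound 2 `O=C(OC1CCC(CN2CCN(c3cc(=O)c4cc(C(F)(F)F)cc([N+](=O)[O-])c4s3)CC2)CC1)c1ccncc1` gives 0.0817 h
Compound 3 `Cc1ccc(C(=O)OC2CCC(CN3CCN(c4cc(=O)c5cc(C(F)(F)F)cc([N+](=O)[O-])c5s4)CC3)CC2)cc1` gives 0.202 h

In an ADME assay on cells (Hepatocyte, Mus musculus) for metabolic stability (on this read-out lower numbers stand for a shorter-lived compound and higher numbers for a longer-lived compound), compound 1 gives > 1.55 h, which is a limit of the assay and not a number. Compound 4 `CC(=O)NC1CCC(CN2CCN(c3cc(=O)c4cc(C(F)(F)F)cc([N+](=O)[O-])c4s3)CC2)CC1` has not been measured. It differs from compound 1 in one place: acetyl in place of methylsulfonyl on an amine nitrogen. This puts acetyl in place of methylsulfonyl on an amine nitrogen.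

For the measured compounds named here, two measured steps touch this group, and both lie beyond the scatter: an at least 18-fold lower number from compound 1 to compound 2 (1.27 log units; beyond the scatter) and an at least 7.6-fold lower number from compound 1 to compound 3 (0.88 log units; beyond the scatter). Each replaces the whole methanesulfonamido, so neither tests acetyl directly. The smaller 2.5-fold higher number from compound 2 to compound 3 (0.39 log units; beyond the scatter) concerns only the group on a carbonyl carbon and bears little on this change.

Compound 4 keeps the amine nitrogen that is lost in an at least 7.6-fold lower number from compound 1 to compound 3 (0.88 log units; beyond the scatter), so a fall of that size is not expected. The estimate is an at least 1.1-fold lower number from compound 1 to compound 4 (0.04 log units; that floor lies within the scatter), which means no expected step beyond the scatter in this assay. For compound 4 the estimated half-life is 1.4 h, within an expected range of 0.5 h to 3 h.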

Compound 4, half-life: > 1.55 h
Compound 4: no number, only a limit; the forecaster's own chance of this, stated with the estimate: 45%; middle value at least 1.1-fold (0.04 log units) away from the limit.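

Compound 4 stands at a limit in this assay, not at a number, and compound 1 stands at the same limit: the limit of > 1.55 h in this assay, at which 2 of the 4 values shown sit. Acetyl on this amine nitrogen therefore serves as well as methylsulfonyl as far as this read-out can show, so the long half-life does not depend on the methylsulfonyl group itself. The two ester compounds fall well short of the acetamido compound, with an at least 7.6-fold higher number from compound 3 to compound 4 (0.88 log units; beyond the scatter) and an at least 18-fold higher number from compound 2 to compound 4 (1.27 log units; beyond the scatter), and among these four compounds none goes against the split between the nitrogen-linked groups and the esters.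

Compound 1 and compound 4 both stand at limits, and the step between them cannot be read. From the compounds shown here alone, whether a free amine or a carboxylic acid on this saturated ring carbon would also reach the limit remains open.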